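Fluoro to chloro on the aromatic ring of compound 2

The source may report more compounds than this note shows. Statements on the series, on what has been measured and on what is new or still open speak of the compounds shown alone.

Measured compounds:
compound 1, `Cc1ccccc1-n1cc(-c2cccc(NS(=O)(=O)c3c[nH]c(=O)[nH]c3=O)c2)nn1`: 15300 nM
compound 2, `O=c1[nH]cc(S(=O)(=O)Nc2cccc(-c3cn(-c4ccccc4F)nn3)c2)c(=O)[nH]1`: "not toxic" (no number reported)

In an ADME assay on L02 cells (Homo sapiens) for cytotoxicity, read by MTT assay, with a stated time of 24 h (on this read-out higher numbers stand for lower toxicity in this test and lower numbers for higher toxicity in this test), compound 1 gives 15300 nM. In this assay compound 2 is reported as "not toxic" (no number reported), so no single number places it on the scale. Compound 3, `O=c1[nH]cc(S(=O)(=O)Nc2cccc(-c3cn(-c4ccccc4Cl)nn3)c2)c(=O)[nH]1`, differs from compound 2 by chloro in place of fluoro on an aromatic carbon. For the measured compounds named here, with no measured step of this kind, the expectation for this assay is a change no larger than the scatter, in no set direction. For compound 3 the half-maximal cytotoxic concentration is estimated at 20000 nM, within 8000 nM to 60000 nM.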

Compound 3, half-maximal cytotoxic concentration: 11500 nM
For compound 3 the middle estimate is 1.7-fold (0.24 log units) above the measured one, and the stated range covers the measured number.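

With chloro in place of methyl on the aromatic carbon, this assay shows a 1.3-fold lower number from compound 1 to compound 3 (0.12 log units; within the scatter), so these two groups read alike at this position. For the compounds shown here, the step from 2-fluorophenyl to 2-chlorophenyl cannot be read: compound 2 is reported as "not toxic" (no number reported), and compound 3 gives the only number among the halogens here. No available evidence bears on this result. The compounds shown leave open how an amine or a carboxylic acid at this position would read in this assay. They also leave open whether fluoro sits on the same scale as chloro.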